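The source may hold more compounds than are shown below. What is called first, only, known or untested is meant among the compounds shown, and "the series" means these compounds.

Compound 1 `COc1ccc(N2CCN(CCC(OC(N)=O)c3ccc(Cl)cc3)CC2)cc1` gives 51% in a functional assay on the whole organism for inhibition, with Mus musculus as the target, in the writhing test, with a stated time of 1 h, at a dose of 10 mg/kg by the oral route; on this read-out higher numbers stand for more inhibition at the one dose given (going by the name of the read-out) and lower numbers for less inhibition; compound 2 `COc1ccc(N2CCN(CCC(OC(N)=O)c3ccc(Cl)c(Cl)c3)CC2)cc1` gives 61%.

Compound 2 holds the higher of the two numbers, though its step from compound 1, a number 10 percentage points higher from compound 1 to compound 2 (within the scatter), lies within the scatter. Compound 3 `COc1ccc(N2CCN(CCC(OC(N)=O)c3ccc(Cl)c(C(F)(F)F)c3)CC2)cc1` differs from compound 2 by trifluoromethyl in place of chloro on an aromatic carbon. Among the compounds with values here, no measured step covers this change; the one step available, which brought in a chloro group, moved the number little. Compound 3 is therefore expected to sit close to compound 2, with an estimated step of a number 1 percentage points lower from compound 2 to compound 3 (within the scatter). The estimate for compound 3 is 60%, ranging from 40% to 78%.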

Compound 3, a percentage reported as inhibition, in the whole organism at one dose (the size of the read-out at that dose, not a potency): 46%
Estimate against measurement, compound 3: 14 percentage points above, within the range that was stated.
By their numbers in this assay, from the lowest: compounds 3, 1 and 2 (each within the scatter of the next, the first and the last beyond it).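

In this assay, within the data shown here, trifluoromethyl in place of chloro, ortho to a chloro group, gives a number 15 percentage points lower from compound 2 to compound 3 (beyond the scatter), the first step here to lie beyond the scatter. Set against hydrogen at the same place, trifluoromethyl gives a number 5 percentage points lower from compound 1 to compound 3 (within the scatter), so the two groups differ from each other at this position, while neither differs from hydrogen beyond the scatter. Nothing at hand accounts for this difference.

Going by these compounds, it remains open how a nitrile or a methyl group at this place would compare with chloro and trifluoromethyl. Also open, on these data alone, is whether the same step would appear with an amine in place of the carbamate.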